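The source may report more compounds than this note shows. Statements on the series, on what has been measured and on what is new or still open speak of the compounds shown alone.

Measured compounds:
- Compound 1 `O=C(c1ccccc1)c1ccccc1OCC(O)CN1CCC(C(=O)Nc2ccccc2)CC1`: 4300 nM
- Compound 2 `O=C(c1ccccc1)c1cccc(OCC(O)CN2CCC(N3Cc4ccccc4C3=O)CC2)c1`: 920 nM

Both compounds were tested in an assay on isolated protein for inhibition of sodium channel protein type 1 subunit alpha (Homo sapiens), read by patch clamp; on this read-out higher numbers stand for weaker inhibition and lower numbers for stronger inhibition. Of the two numbers, compound 2 has the lower one: in this assay compound 2 gives 920 nM, while compound 1 gives 4300 nM, a gap that lies beyond the usual scatter of repeated measurements. Among the measured compounds shown here, no single-point step connects these two compounds, so the gap is simply what the two values show.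

Compound 3 `O=C1c2ccccc2CN1C1CCN(CC(O)COc2cccc(C(F)(F)F)c2)CC1` has not yet been measured. It is built from compound 2 by one change: trifluoromethyl in place of benzoyl on an aromatic carbon. A large group carrying its own aromatic ring and one hydrogen-bond acceptor is thus exchanged for a small group with neither ring nor acceptor. For the measured compounds named here, the data hold no measured step of this kind, so the expected size of the change is uncertain.

For compound 3 the expectation is a moderate shift toward weaker inhibition, a 2.7-fold higher number from compound 2 to compound 3 (0.43 log units; beyond the scatter), lying on the edge of the scatter rather than far beyond it. In this assay compound 3 is therefore estimated at 2500 nM, with a plausible range from 800 nM to 8000 nM.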

Compound 3, half-maximal inhibitory concentration: 1200 nM
Compound 3: the middle estimate sits 2.1-fold (0.32 log units) above what was measured; the range from low to high includes it.
By their numbers in this assay, from the lowest: compounds 2 and 3 (each within the scatter of the next); then compound 1.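

In this assay, trifluoromethyl in place of benzoyl gives a 1.3-fold higher number from compound 2 to compound 3 (0.12 log units; within the scatter) at this aromatic carbon, meta to a large group. Among the compounds shown here, this is the first step that changes only one place, and it shows that inhibition at the level of compound 2 does not depend on benzoyl here: trifluoromethyl, which has neither the aromatic ring nor the hydrogen-bond acceptor of benzoyl, gives a value within the scatter of it. Nothing in the data explains why the two groups read alike.

The compounds shown leave open whether almost any group is tolerated on this carbon or whether some substituent is needed at all, a question that a plain hydrogen, a methoxy group, an amine or a carboxylic acid in the same place would help to answer. Also open, from the compounds shown here alone, is whether the same exchange would give a similar result on the core of compound 1, which differs from compound 2 in more than one place.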